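The compounds below may be only part of what the source reports. "The series", "measured", "known", "first", "only" and "open" are said of these compounds alone.

Compound 2 `Cc1cc(C)nc(NC(=S)NC(=O)c2c(-c3ccc(Cl)cc3Cl)noc2C)n1` is the stronger of the two compounds tested in a functional assay on the whole organism for inhibition, with Chenopodium ficifolium as the target, with a stated time of 72 h, tested at 100 mg/L (a higher number here means more inhibition of growth at the concentration tested, a lower number less inhibition of growth), where compound 2 gives 65.4%. Among the compounds with values here, its only neighbour, compound 1 `Cc1cc(O)nc(NC(=S)NC(=O)c2c(-c3ccc(Cl)cc3Cl)noc2C)n1`, gives 46.7% in this assay, and the step of a number 18.7 percentage points higher from compound 1 to compound 2 (beyond the scatter) changed the same ring. Compound 3 `COc1cc(OC)nc(NC(=S)NC(=O)c2c(-c3ccc(Cl)cc3Cl)noc2C)n1` differs from compound 2 by 4,6-dimethoxypyrimidin-2-yl in place of 4,6-dimethylpyrimidin-2-yl on an amide-type nitrogen. Within the data shown here, the single measured step touches that ring but swaps different groups, so it guides only loosely; a small drop or none beyond the scatter is expected. Compound 3 is estimated at 55%, within 30% to 78%, a step of a number 10.4 percentage points lower from compound 2 to compound 3 (beyond the scatter).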

Compound 3, percent growth inhibition at one concentration: 78.6%
Estimate against measurement, compound 3: 23.6 percentage points below; measured number outside the range, above it.
By their numbers in this assay, from the lowest: compound 1; then compound 2; then compound 3.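

On the amide-type nitrogen, replacing 4,6-dimethylpyrimidin-2-yl with 4,6-dimethoxypyrimidin-2-yl in this assay gives a number 13.2 percentage points higher from compound 2 to compound 3 (beyond the scatter) and shows that this position can still gain beyond the level of compound 2. The same group in place of 4-hydroxy-6-methylpyrimidin-2-yl gives a number 31.9 percentage points higher from compound 1 to compound 3 (beyond the scatter) and so widens the range seen at this position. Nothing shown here bears on the reason for these rises. As far as these compounds go, whether longer ethoxy groups or amines such as those in 4,6-diaminopyrimidin-2-yl would keep or lose this gain remains open. So does the effect of a single methoxy group paired with a methyl.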